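The compounds below may be only part of what the source reports. "The series", "measured", "known", "first", "only" and "open" are said of these compounds alone.

Measured so far in a functional assay on BeWo cells (Homo sapiens) for inhibition, read by MTT assay; a lower number here means a stronger inhibitor, a higher number a weaker inhibitor:
- compound 1, `CC1(C)C2CCC1(C)C(OC(=O)/C=C/c1cc(O)c(O)c(Cl)c1)C2`: compound 1 gives 51900 nM
- compound 2, `CC1(C)C2CCC1(C)C(OC(=O)/C=C/c1ccc(O)c(O)c1[N+](=O)[O-])C2`: compound 2 gives 9310 nM
- compound 3, `O=C(/C=C/c1ccc(O)c(O)c1[N+](=O)[O-])OCCc1ccccc1`: compound 3 gives 4380 nM

Compound 1 has the highest number of the three in this assay, and so is the weakest inhibitor of this set; its gap to compound 2 and its gap to compound 3 are both beyond the scatter. Within the data shown here, compounds 2 and 3 share a nitro-bearing catechol and differ from compound 1 in more than one place, so no single-change step is available among the measured compounds.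

Compound 4, `CC1(C)C2CCC1(C)C(OC(=O)/C=C/c1cc(O)c(O)c(Br)c1)C2`, keeps the whole core of compound 1 and differs only in the halogen on the ring: bromo in place of chloro on an aromatic carbon. Among the measured compounds shown here, the measured set holds no pair that differs by a halogen swap alone, so there is no direct precedent for the size of this step. A change of this kind is expected to move the number little; the step of a 1.2-fold lower number from compound 1 to compound 4 (0.06 log units; within the scatter) is estimated to fall within the scatter, if anything towards a slightly lower number. Compound 4 is therefore expected to give about 45000 nM in this assay, with a plausible range of 20000 nM to 100000 nM.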

Compound 4, half-maximal inhibitory concentration: 20000 nM
Estimate against measurement, compound 4: 2.3-fold (0.35 log units) above, and the stated range covers the measured number.
By their numbers in this assay, from the lowest: compound 3; then compound 2; then compound 4; then compound 1.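

In this assay the series now has its first single-change reading: bromo in place of chloro, on an aromatic carbon ortho to a hydroxy group, gives a 2.6-fold lower number from compound 1 to compound 4 (0.41 log units; beyond the scatter) and is a modest step. With the rest of compound 1 held constant, the number at this position therefore responds to the identity of the halogen, and a chloro-to-bromo swap alone moves it beyond the scatter. Nothing at hand explains the direction or size of this step.

As far as these compounds go, whether the trend continues to other groups at this position, such as fluoro, iodo, methoxy or an amine, remains open. Also open, from the compounds shown here alone, is whether the same swap gives a similar step on the ester of compound 3, where the ring carries a nitro group instead of a halogen.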